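Working notes on a cytotoxicity series: halogen swap on the aryl group

This account rests on a few compounds, and the source may have more. Where it says the series, first, only, none or still open, it means among the compounds named here.

Measured so far:
compound 1 `CCC(c1cc(O)nc(SC(C)C)n1)c1c(Cl)cccc1Cl` — > 200000 nM (a limit of the assay)
compound 2 `CCC(c1cc(O)nc(SC2CCCCC2)n1)c1c(Cl)cccc1Cl` — 200000 nM

Among the compounds with values here, in a functional assay on MT4 cells (Homo sapiens) for cytotoxicity (a lower number here means that less compound is tolerated, a higher number that more compound is tolerated), compound 2 gives the only number in the set. Compound 1 gives > 200000 nM, which is a limit of the assay and not a number. Within the data shown here, the one measured step is a number no higher from compound 1 to compound 2 (the limit leaves the size open); its size is not readable because the limit of > 200000 nM in this assay, at which 1 of the 2 values shown sits, caps one of the two values, so it only says that compound 2 is no better tolerated than the limit allows.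

The next compound is compound 3 `CCC(c1cc(O)nc(SC2CCCCC2)n1)c1c(F)cccc1F`, which differs from compound 2 by 2,6-difluorophenyl in place of 2,6-dichlorophenyl on a saturated chain carbon bound to an aromatic carbon and a saturated chain carbon. Among the measured compounds shown here, no measured step touches this position, and the only step on record concerns a different part of the molecule and has no readable size, so there is nothing to scale an expectation by. Given that both measured compounds sit at the top of this assay, compound 3 is expected to stay there as well, with a step of no change at the digits printed from compound 2 to compound 3 (within the scatter) that is not expected to exceed the scatter. For compound 3 the estimate in this assay is 200000 nM, with a range from 100000 nM to 400000 nM, and a real chance that only a limit is reported.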

Compound 3, half-maximal cytotoxic concentration: > 200000 nM
Compound 3 was reported as a limit (the forecaster's own chance of this, stated with the estimate: 50%); the middle value lies on the limit itself.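

In this assay, the one change shown on the saturated chain carbon bound to an aromatic carbon and a saturated chain carbon, 2,6-difluorophenyl in place of 2,6-dichlorophenyl, gives a number no lower from compound 2 to compound 3 (the limit leaves the size open). Compound 3 gives > 200000 nM, which is a limit of the assay. The two halogen patterns therefore cannot be ranked against each other and the size of the step cannot be read, because the values sit at one limit: the limit of > 200000 nM in this assay, at which 2 of the 3 values shown sit.

From the compounds shown here alone, it remains open whether any group at this position would bring a readable number in this assay, such as an amine or a carboxylic acid on the aryl group, or an unsubstituted phenyl in place of the dihalophenyl groups. Going by these compounds, it is also open whether the same swap would read any differently with the isopropyl on the sulfur of compound 1 than with the cyclohexyl of compound 2.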